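The source may report more compounds than this note shows. Statements on the series, on what has been measured and on what is new or still open speak of the compounds shown alone.

Working notes on a series built on the shared core of compound 1 `CC(C)N(Cc1cccc(OCCCCCC(=O)O)c1)C(=O)c1ccc(-c2cccc3ccccc23)cc1`. In an ADME assay on HepG2 cells (Homo sapiens) for cytotoxicity, read by CellTiter-Glo and resazurin assay, with a stated time of 72 h (a higher number here means that more compound is needed for the effect, a lower number that less compound is needed), compound 1 gives > 26000 nM, which is a limit of the assay rather than a number. Compound 2 `CC(=O)c1cccc(-c2ccc(C(=O)N(Cc3cccc(OCCCCCC(=O)O)c3)C(C)C)cc2)c1` carries 3-acetylphenyl in place of naphthalen-1-yl on an aromatic carbon; in this assay compound 2 gives > 26000 nM, again a limit. Compound 3 `CC(C)N(Cc1cccc(OCCCCCC(=O)O)c1)C(=O)c1ccc(-c2ccoc2)cc1` carries furan-3-yl in place of naphthalen-1-yl on an aromatic carbon; in this assay compound 3 gives > 26000 nM, also a limit. Compound 2 thus stands at a limit, and the two further values shown are limits as well, as the limit of > 26000 nM in this assay, at which 3 of the 3 values shown sit, records. The steps a step that the two limits leave unreadable from compound 1 to compound 2, a step that the two limits leave unreadable from compound 1 to compound 3 and a step that the two limits leave unreadable from compound 2 to compound 3 are therefore all unreadable in size.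

Compound 4 `CC(C)N(Cc1cccc(OCCCCCC(=O)O)c1)C(=O)c1ccc(-c2cccc(OCc3ccccc3)c2)cc1` differs from compound 2 by benzyloxy in place of acetyl on an aromatic carbon. Among the compounds with values here, the steps that bear on it are those that exchange the group on this aromatic carbon, from compound 1 to compound 2 and from compound 2 to compound 3, and neither gave a readable size. No step beyond the scatter is expected in this assay, and a further limit is the likely outcome. Compound 4 is expected to give 40000 nM in this assay, within 15000 nM to 150000 nM. The estimated step that the limit leaves unreadable from compound 2 to compound 4 is expected to stay within the scatter.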

Compound 4, half-maximal effective concentration: > 26000 nM
Compound 4: no number, only a limit; the forecaster's own chance of this, stated with the estimate: 85%; the middle value lies beyond the limit too.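

In this assay compound 4 gives > 26000 nM, again a limit and not a number. The exchange between compound 2 and compound 4 therefore yields no new step of readable size: the limit of > 26000 nM in this assay, at which 4 of the 4 values shown sit.

The compounds shown leave open at what concentration compound 1, compound 2, compound 3 or compound 4 would reach the half-maximal effect, and whether the group on this aromatic carbon alters it.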